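Replacing a carbamoylmethyl group with an isopropylcarbonyl group

This account rests on a few compounds, and the source may have more. Where it says the series, first, only, none or still open, it means among the compounds named here.

Compound 1 `Cc1c(F)c(Oc2cccc(C(=N)N)c2)nc(Oc2cccc(C(=O)N3CCOCC3)c2)c1F`: in an assay on isolated protein for inhibition of serine protease 1 (Bos taurus) (on this read-out higher numbers stand for weaker inhibition and lower numbers for stronger inhibition), compound 1 reaches only the limit > 5000 nM.
Compound 2 `Cc1c(F)c(Oc2cccc(C(=N)N)c2)nc(Oc2cccc(-n3ccnc3)c2)c1F`: in this assay compound 2 gives 4800 nM.
Compound 3 `Cc1c(F)c(Oc2cccc(CC(N)=O)c2)nc(Oc2cccc(C(=N)N)c2)c1F`: in this assay compound 3 reaches only the limit > 5000 nM.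

Compound 3 thus stands at the limit of the assay, a limit shared by one other value (the limit of > 5000 nM in this assay, at which 2 of the 3 values shown sit). Compound 4 `Cc1c(F)c(Oc2cccc(C(=N)N)c2)nc(Oc2cccc(C(=O)C(C)C)c2)c1F` differs from compound 3 in one place: isopropylcarbonyl in place of carbamoylmethyl on an aromatic carbon. The measured steps that touch compound 3 say little: a step that the two limits leave unreadable from compound 1 to compound 3 and an at least 1.0-fold higher number from compound 2 to compound 3 (0.01 log units; that floor lies within the scatter); the remaining comparison, an at least 1.0-fold lower number from compound 1 to compound 2 (0.01 log units; that floor lies within the scatter), also lies within the scatter. All three values sit at or near the limit, so compound 4 is expected to stay there too, the expected step being a number no higher from compound 3 to compound 4 (the limit leaves the size open). Compound 4 is therefore estimated at 5000 nM, with a range from 1500 nM to 20000 nM, and most likely reported only as a limit.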

Compound 4, inhibition constant: 3800 nM
Estimate against measurement, compound 4: 1.3-fold (0.12 log units) above, within the range that was stated.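

Putting isopropylcarbonyl in place of carbamoylmethyl gives an at least 1.3-fold lower number from compound 3 to compound 4 (0.11 log units; that floor lies within the scatter), and its true size stays hidden because one end of the step is a limit: the limit of > 5000 nM in this assay, at which 2 of the 4 values shown sit.

Against the other groups, isopropylcarbonyl in place of 1H-imidazol-1-yl gives a 1.3-fold lower number from compound 2 to compound 4 (0.10 log units; within the scatter), and isopropyl in place of morpholin-4-yl on the carbonyl carbon gives an at least 1.3-fold lower number from compound 1 to compound 4 (0.11 log units; that floor lies within the scatter). So no readable step at this position yet goes beyond the scatter, even with a group that has no hydrogen-bond donor.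

From the compounds shown here alone, whether an amine, a carboxylic acid or a longer chain here would move the number beyond the scatter in this assay stays open.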